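The source may report more compounds than this note shows. Statements on the series, on what has been measured and on what is new or still open speak of the compounds shown alone.

Values in a functional assay on CCRF-CEM cells (Homo sapiens) for cytotoxicity, in the absence of a further agent (on this read-out higher numbers stand for weaker inhibition and lower numbers for stronger inhibition), for the measured compounds:

compound 1, `Nc1nc(N)c(CCCN(Cc2ccc(NC(CCC(=O)O)C(=O)O)cc2)c2cc(F)c([N+](=O)[O-])cc2[N+](=O)[O-])c(O)n1`, gives 44000 nM
compound 2, `COC(=O)c1ccc(CN(CCCc2c(N)nc(N)nc2O)c2cc(F)c([N+](=O)[O-])cc2[N+](=O)[O-])cc1`, gives 3900 nM
compound 3, `Nc1nc(N)c(CCCN(Cc2ccc(NC(CCC(=O)O)C(=O)O)cc2)c2ccc([N+](=O)[O-])c(F)c2F)c(O)n1`, gives only a limit in this assay, > 100000 nM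

Compound 1 and compound 2 differ in one place: methoxycarbonyl in place of (1,3-dicarboxypropyl)amino on an aromatic carbon. That change gives an 11-fold lower number from compound 1 to compound 2 (1.05 log units; beyond the scatter).

Compound 3 carries the same (1,3-dicarboxypropyl)amino group as compound 1, but the difference between the two cores is not broken down here. The reading for compound 3 is a limit of this assay and not a number, at the limit of > 100000 nM in this assay, at which 1 of the 3 values shown sits.

Compound 4, `COC(=O)c1ccc(CN(CCCc2c(N)nc(N)nc2O)c2ccc([N+](=O)[O-])c(F)c2F)cc1`, is not yet measured in this assay. It differs from compound 3 in one place: methoxycarbonyl in place of (1,3-dicarboxypropyl)amino on an aromatic carbon. The place is the same, word for word, as in the pair of compound 1 and compound 2, so this is the same change, seen twice among the compounds shown.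

If the change acts as it did between compound 1 and compound 2, a step of similar size is expected from compound 3 to compound 4, an at least 3.3-fold lower number from compound 3 to compound 4 (0.52 log units; beyond the scatter), resting on the step of an 11-fold lower number from compound 1 to compound 2 (1.05 log units; beyond the scatter) and on the limit of compound 3. Because compound 3 sits at a limit, (the limit of > 100000 nM in this assay, at which 1 of the 3 values shown sits), the starting point is not a number, and the estimate for compound 4 is correspondingly wide. Compound 4 is expected to give about 30000 nM in this assay, estimated between 8000 nM and 150000 nM.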

Compound 4, half-maximal inhibitory concentration: 45000 nM
Compound 4: middle estimate off by 1.5-fold (0.18 log units), on the low side; low and high end bracket the measured number.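

In this assay, methoxycarbonyl in place of (1,3-dicarboxypropyl)amino on an aromatic carbon goes with an at least 2.2-fold lower number from compound 3 to compound 4 (0.34 log units; beyond the scatter) on the core of compound 3, so the direction seen on the core of compound 1 carries over to a second core. Set beside the earlier step, this is one repeat of the direction and no measure of how far the size carries over: the same change on two cores in this assay, an 11-fold lower number (1.05 log units; beyond the scatter) from compound 1 to compound 2 and an at least 2.2-fold lower number (0.34 log units; beyond the scatter) from compound 3 to compound 4; the limit leaves it open whether they differ

Compound 3 gives > 100000 nM, which is a limit and not a number, so a step of equal size on both cores is not shown, and neither is a smaller one: the limit of > 100000 nM in this assay, at which 1 of the 4 values shown sits.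

The compounds shown leave open how a single carboxylic acid or a primary amide on that aromatic carbon would read in this assay, and so whether the step follows the loss of (1,3-dicarboxypropyl)amino or the arrival of methoxycarbonyl. They also leave open whether the same direction would hold with a longer chain on the shared core, since two pairs on two cores are all that bear on this change.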